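The source may report more compounds than this note shows. Statements on the series, on what has been measured and on what is new or still open speak of the compounds shown alone.

Measured compounds:
- compound 1, `CC(=O)c1ccc(Nc2ccnc(-c3ccncc3)n2)cc1`: 37000 nM
- compound 2, `CCOC(=O)c1ccc(Nc2cc(C)nc(-c3ccncc3)n2)cc1`: 4000 nM

Of the compounds shown here, two have been measured in a physicochemical assay for solubility, in phosphate buffer; a lower number here means a less soluble compound, a higher number a more soluble compound. Compound 1 gives 37000 nM. Compound 2 gives 4000 nM, the lower of the two numbers, and the gap between the two lies beyond the usual scatter of repeated measurements. The two compounds differ in more than one place, so no single step can be read from them.

The next compound, compound 3, `CC(=O)c1ccc(Nc2cc(C)nc(-c3ccncc3)n2)cc1`, differs from compound 2 in one place only: methyl in place of ethoxy on a carbonyl carbon. In words, a methyl takes the place of an ethoxy on a carbonyl carbon, so the group on that carbon changes from ethoxycarbonyl to acetyl, and the molecule becomes smaller by this exchange. Compound 3 then carries the same acetyl group as compound 1 together with the same core as compound 2.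

Because compound 1, which bears the acetyl group, gives 37000 nM, the expectation is that compound 3 will land somewhere between the two measured numbers, an expected step from compound 2 of a 2.5-fold higher number from compound 2 to compound 3 (0.40 log units; beyond the scatter) toward a higher number. For compound 3 the estimated solubility in this assay is 10000 nM, with a range from 3000 nM to 40000 nM.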

Compound 3, solubility: 6000 nM
Beside the measured number, compound 3's estimate is 1.7-fold (0.22 log units) above it; the range from low to high includes it.
By their numbers in this assay, from the lowest: compounds 2 and 3 (each within the scatter of the next); then compound 1.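

Exchanging ethoxy for methyl on a carbonyl carbon gives, in this assay, a 1.5-fold higher number from compound 2 to compound 3 (0.18 log units; within the scatter), so with this shared core the numbers for ethoxycarbonyl and acetyl cannot be told apart. Among these compounds, the new structure also gives the first readable step for methyl in place of hydrogen on an aromatic carbon, with acetyl held constant: a 6.2-fold lower number from compound 1 to compound 3 (0.79 log units; beyond the scatter), and of the two single changes now available, only this one lies beyond the scatter. Nothing measured here explains either step, so the numbers record what happens without showing the reason.

The methyl step is shown only with acetyl on the carbonyl carbon, so it remains open whether the same exchange would give a similar step with ethoxycarbonyl in that place. The compounds shown also leave open how an amine or a hydroxyl on the carbonyl carbon would compare with ethoxy and methyl, and whether a longer chain in place of the methyl on the aromatic carbon would move the number in the same direction.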